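The source may report more compounds than this note shows. Statements on the series, on what has been measured and on what is new or still open speak of the compounds shown alone.

In a functional assay on A-427 cells (Homo sapiens) for cytotoxicity, read by colorimetric assay and MTT assay (on this read-out lower numbers stand for stronger inhibition and higher numbers for weaker inhibition), compound 1 `COc1cc(OC)c2cc(-c3ccc(OCc4ccccc4)cc3)c(O)nc2c1` gives 10000 nM. Compound 2 `CCOC(=O)Cn1c(=O)c(-c2ccc(OC)cc2)cc2c(OC)cc(OC)cc21` gives 10000 nM, which places compound 2 level with compound 1, with no difference beyond the usual scatter of repeated measurements.

Compound 3 `COc1ccc(-c2cc3c(OC)cc(OC)cc3n(CC(=O)O)c2=O)cc1` matches compound 2 except for one change, in the ester at the end of the side chain: hydrogen in place of ethyl on an oxygen next to a carbonyl group. Hydrogen replaces ethyl on an oxygen next to a carbonyl group, so ethoxycarbonyl becomes carboxy and (ethoxycarbonyl)methyl becomes carboxymethyl.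

Among the compounds with values here, no two tested compounds differ in only one place, so no measured step shows what a change like this does in this assay. Within the data shown here, the only guides are the two readings, with compound 1 at 10000 nM and compound 2 at 10000 nM. With so little to go on, no direction can be favoured, and no shift beyond the scatter is expected. The expected step of no change at the digits printed from compound 2 to compound 3 (within the scatter) is therefore small. Compound 3 is estimated at 10000 nM, with an expected range of 4000 nM to 25000 nM.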

Compound 3, half-maximal inhibitory concentration: 10000 nM
Beside the measured number, compound 3's estimate shows no gap at the digits printed, and the stated range covers the measured number.
By their numbers in this assay, from the lowest: compounds 1, 2 and 3 (each within the scatter of the next).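

In this assay, replacing ethyl with hydrogen on an oxygen next to a carbonyl group gives the first step measured between two compounds that differ in one place: no change at the digits printed from compound 2 to compound 3 (within the scatter). This shows that, on this core, changing (ethoxycarbonyl)methyl to carboxymethyl leaves the reading level, something the earlier readings could not show without such a step. Nothing available explains why this step shows no change.

The compounds shown leave open whether a different end to this side chain, such as an amide or an amine, or a longer chain in place of carboxymethyl, would move the reading away from this level. They also leave open whether replacing ethyl with hydrogen in the same way would read the same on another core, since this is a single step on a single core.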